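Moving the nitrile: compound 2 to compound 4

The compounds below may be only part of what the source reports. "The series", "measured", "known", "first", "only" and "open" are said of these compounds alone.

- compound 1 `COc1cc2c(Nc3cccc(C#N)c3)ncnc2cc1OCCCN1CCCCC1`: 37000 nM
- compound 2 `COc1cc2c(Nc3cccc(C#N)c3)ncnc2cc1OCCCN1CCN(C)CC1`: 27700 nM
- compound 3 `CCN1CCN(CCCOc2cc3ncnc(Nc4cccc(C#N)c4)c3cc2OC)CC1`: 18700 nM

In a functional assay on A549 cells (Homo sapiens) for antiproliferative activity, read by MTT assay, with a stated time of 72 h (a higher number here means a weaker inhibitor, a lower number a stronger inhibitor), compound 2 gives 27700 nM, and it is not separated beyond the scatter from either of the other two compounds.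

Compound 4 `COc1cc2c(Nc3ccccc3C#N)ncnc2cc1OCCCN1CCN(C)CC1` differs from compound 2 as follows: 2-cyanophenyl in place of 3-cyanophenyl on a nitrogen on an aromatic ring. This places 2-cyanophenyl in place of 3-cyanophenyl on a nitrogen on an aromatic ring.

The measured steps are a 1.3-fold lower number from compound 1 to compound 2 (0.13 log units; within the scatter), a 2.0-fold lower number from compound 1 to compound 3 (0.30 log units; within the scatter) and a 1.5-fold lower number from compound 2 to compound 3 (0.17 log units; within the scatter). All of them exchange piperidin-1-yl, 4-methylpiperazin-1-yl or 4-ethylpiperazin-1-yl at the end of the chain, and none alters the cyanophenyl group. They therefore bear on this change only indirectly, and the series holds no measurement of a shifted nitrile. No step beyond the scatter is expected in this assay, in either direction, though the range is kept wide.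

The expected change is a 1.2-fold higher number from compound 2 to compound 4 (0.06 log units; within the scatter).

Compound 4 is estimated at 32000 nM, with an expected range of 12000 nM to 80000 nM.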

Compound 4, half-maximal inhibitory concentration: 23400 nM
Estimate against measurement, compound 4: 1.4-fold (0.14 log units) above; low and high end bracket the measured number.
By their numbers in this assay, from the lowest: compounds 3, 4, 2 and 1 (each within the scatter of the next).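

In this assay, among the compounds shown here, moving the nitrile gives a 1.2-fold lower number from compound 2 to compound 4 (0.07 log units; within the scatter) and is the first step that touches the cyanophenyl group rather than the chain end. On a nitrogen on an aromatic ring, 2-cyanophenyl and 3-cyanophenyl therefore cannot be told apart in this assay, at least with 4-methylpiperazin-1-yl at the end of the chain. No supporting measurement is available to explain this result.

From the compounds shown here alone, it remains open whether 4-cyanophenyl, or an ethynyl or chloro group in place of the nitrile, would also stay within the scatter of compound 2. Also open, going by these compounds, is whether 2-cyanophenyl would read the same with piperidin-1-yl or 4-ethylpiperazin-1-yl at the end of the chain.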